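The source may hold more compounds than are shown below. What is called first, only, known or untested is meant among the compounds shown, and "the series" means these compounds.

Working notes on the series. Compound 1 `O=C1O[C@H]([C@@H](O)Cn2cc(-c3cccc(O)c3)nn2)C(OCc2ccccc2)=C1OCc1ccccc1` was run in a functional assay on CFPAC-1 cells (Homo sapiens) for antiproliferative activity, read by MTT assay, with a stated time of 72 h; on this read-out higher numbers stand for weaker inhibition and lower numbers for stronger inhibition. In this assay compound 1 gives 54100 nM. Among the compounds with values here, that is the only number in the set; the other result is a limit. Compound 2 `O=C1O/C(=C\Cn2cc(-c3cc(C(F)(F)F)cc(C(F)(F)F)c3)nn2)C(OCc2ccccc2)=C1OCc1ccccc1` reaches no number in this assay: compound 2 returns > 100000 nM, which is a limit of the assay and not a measured value. For compound 2 this is the limit of > 100000 nM in this assay, at which 1 of the 2 values shown sits. Within the data shown here, compound 1 therefore stands as the sole compound with a measured concentration, and that concentration sits far up the scale, a weak inhibitor.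

Compound 3 `O=C1O[C@H]([C@@H](O)Cn2cc(-c3ccc(Br)cc3)nn2)C(OCc2ccccc2)=C1OCc1ccccc1` is not yet measured in this assay. Relative to compound 1 the change is 4-bromophenyl in place of 3-hydroxyphenyl on an aromatic carbon. Among the measured compounds shown here, no measured pair in the set shares this change, so there is no step to lean on; the change that separates compound 2 from compound 1 is a different one, and compound 2 gave only a limit. The step of a 1.1-fold lower number from compound 1 to compound 3 (0.03 log units; within the scatter) is expected to stay within the usual scatter, with no clear direction. Compound 3 is estimated at 50000 nM, in the range 18000 nM to 140000 nM, with a real chance that the assay again returns only a limit.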

Compound 3, half-maximal inhibitory concentration: 5830 nM
For compound 3 the middle estimate is 8.6-fold (0.93 log units) above the measured one, and the stated range ends above it.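

The aromatic carbon of the five-membered aromatic ring with 3 nitrogen proves responsive in this assay: 4-bromophenyl in place of 3-hydroxyphenyl gives a 9.3-fold lower number from compound 1 to compound 3 (0.97 log units; beyond the scatter). Within the data shown here, this is the first step that can be read, and it shows that the aryl group at this place can shift the read-out beyond the scatter while the rest of compound 1 stays unchanged. Nothing at hand accounts for the step, which is recorded here as an observation only.

Among these compounds, the single step changes three things at once: the hydroxyl leaves, bromine enters, and the substituent's ring position changes from 3 to 4, so their separate contributions remain unresolved. Unsubstituted phenyl, 3-bromophenyl, 4-hydroxyphenyl and 4-chlorophenyl are not among the compounds shown, so it stays open whether the step belongs to bromine itself, to the 4-position or to the loss of the hydroxyl.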